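The compounds below may be only part of what the source reports. "The series", "measured", "known", "first", "only" and "open" are said of these compounds alone.

Compound 1 `O=c1[nH]c2ccccc2n1C/C=C/CN1CCN(C(c2ccccc2)c2ccccc2)CC1`: in an assay on RPMI-8226 cells for antagonist activity at P2X purinoceptor 7 (Homo sapiens), read by calcium flux (on this read-out higher numbers stand for weaker inhibition and lower numbers for stronger inhibition), compound 1 gives > 10000 nM, which is a limit of the assay and not a number (the limit of > 10000 nM in this assay, at which 1 of the 3 values shown sits).
Compound 2 `Cc1nc2ccccc2n1CCCCN1CCN(C(c2ccccc2)c2ccccc2)CC1`: in this assay compound 2 gives 850 nM.
Compound 3 `c1ccc(-c2nc3ccccc3n2CCCCN2CCN(C(c3ccccc3)c3ccccc3)CC2)cc1`: in this assay compound 3 gives 1200 nM.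
Compound 4 `Cc1cccc2ccn(CCCCN3CCN(C(c4ccccc4)c4ccccc4)CC3)c12`: not yet measured in this assay.

Compound 2 stands at one of only two numbers shown, and the other, from compound 3, differs by a 1.4-fold higher number from compound 2 to compound 3 (0.15 log units; within the scatter), a step within the scatter, so the two compounds cannot be told apart on these results. The change that leads to compound 4 is 7-methyl-1H-indol-1-yl in place of 2-methyl-1H-benzimidazol-1-yl on a saturated chain carbon, four bonds along the chain from an amine nitrogen in a ring. Within the data shown here, the single measured step, a 1.4-fold higher number from compound 2 to compound 3 (0.15 log units; within the scatter), swaps the group carried on an aromatic carbon of the shared core while leaving the ring itself untouched, and it moved the number hardly at all. Among the measured compounds shown here, the change to compound 4 alters the ring atoms of the core instead, a kind of change that no measured step covers, so the expectation rests mainly on the shared chain and piperazine portion staying the same. Compound 4 is therefore expected to move by a 1.8-fold higher number from compound 2 to compound 4 (0.25 log units; within the scatter), with wide uncertainty. The estimate for compound 4 is 1500 nM, within a range from 400 nM to 6000 nM.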

Compound 4, half-maximal inhibitory concentration: 2300 nM
For compound 4 the middle estimate is 1.5-fold (0.19 log units) below the measured one, within the range that was stated.
By their numbers in this assay, from the lowest: compounds 2, 3 and 4 (each within the scatter of the next, the first and the last beyond it). At a limit, above all of these: compound 1.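

Unlike the earlier swap on an aromatic carbon, this change replaces the group on the saturated chain carbon itself, and in this assay it gives a 2.7-fold higher number from compound 2 to compound 4 (0.43 log units; beyond the scatter). So the group at this place is not freely interchangeable, although the step is modest and compound 4 still gives a measured number rather than a limit. The entering group has one hydrogen-bond acceptor where the leaving group has two, but nothing measured here explains the rise.

The change replaces a ring nitrogen with carbon and also puts the methyl in a different place, and these compounds cannot separate the two effects. Going by these compounds, how an amine in place of that methyl, or a longer chain, would read also remains open.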